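Lengthening the chloroalkyl amide chain on an anilide core

A few compounds are considered here, and "the series" means these few. Any claim that something is new, unique, unknown or untested is made for them only; others in the source may bear on it.

Compound 1 `CCCCC(O)c1cccc(NC(=O)NCCCCl)c1` carries a urea link, and in a functional assay on HT-29 cells (Homo sapiens) for antiproliferative activity, with a stated time of 48 h (on this read-out higher numbers stand for weaker inhibition and lower numbers for stronger inhibition), compound 1 gives 19000 nM. Compound 2 `CCCCC(O)c1cccc(NC(=O)CCCl)c1` carries a shorter amide in its place. In this assay compound 2 reaches only a limit, > 100000 nM, which is the limit of > 100000 nM in this assay, at which 1 of the 2 values shown sits. That single change gave an at least 5.2-fold higher number from compound 1 to compound 2 (0.72 log units; beyond the scatter). Compound 3 `CCCCC(O)c1cccc(NC(=O)CCCCl)c1` differs from compound 2 by chloromethyl in place of chloro on a saturated chain carbon, two bonds along the chain from a carbonyl carbon. For the measured compounds named here, no measured step covers this exact change, so the expectation leans on the one measured step alone. Compound 3 is therefore expected to show an at least 1.6-fold lower number from compound 2 to compound 3 (0.22 log units; that floor lies within the scatter). The estimate for compound 3 is 60000 nM, between 15000 nM and 200000 nM.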

Compound 3, half-maximal inhibitory concentration: > 100000 nM
Compound 3: only a limit was reported; the forecaster's own chance of this, stated with the estimate: 50%; middle value at least 1.6-fold (0.22 log units) from the limit.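

Lengthening the chain, with chloromethyl in place of chloro, brings no readable change in this assay, since the step between compound 2 and compound 3 cannot be read. With the 3-chloropropyl chain kept and only the amino link of the urea removed, the change gives an at least 5.2-fold higher number from compound 1 to compound 3 (0.72 log units; beyond the scatter), so the longer chain alone does not recover the activity seen with the urea. The two amides cannot be ranked because both stop at the same limit: the limit of > 100000 nM in this assay, at which 2 of the 3 values shown sit.

From the compounds shown here alone, whether a longer chloroalkyl chain on the amide would give a value inside the assay's range remains open. So does the effect of an amine in place of the chlorine.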